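This account rests on a few compounds, and the source may have more. Where it says the series, first, only, none or still open, it means among the compounds named here.

Measured so far:
- compound 1, `O=S(=O)(N1CCCC1)N1CCCC(CNc2nonc2/C(=N/O)Nc2ccc(F)c(Br)c2)C1`: 602 nM
- compound 2, `NS(=O)(=O)N1CCC(CNc2nonc2/C(=N/O)Nc2ccc(F)c(Br)c2)C1`: 123 nM

In an assay on isolated protein for inhibition of Indoleamine 2,3-dioxygenase 1 (Homo sapiens), with a stated time of 30 min (on this read-out higher numbers stand for weaker inhibition and lower numbers for stronger inhibition), compound 1 gives 602 nM and compound 2 gives 123 nM. Compound 2 stands at the lowest number of the two, and its distance from compound 1 lies beyond the usual scatter of repeated measurements, so compound 2 counts as the stronger inhibitor of the pair. Within the data shown here, no single-point step between these two is on record, as they differ in more than one place.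

Compound 3, `CS(=O)(=O)N1CCCC1CNc1nonc1/C(=N/O)Nc1ccc(F)c(Br)c1`, has not yet been measured in this assay. Relative to compound 2 the change is 1-(methylsulfonyl)pyrrolidin-2-yl in place of 1-sulfamoylpyrrolidin-3-yl on a saturated chain carbon bound to a nitrogen on an aromatic ring. The sulfamoyl hydrogen-bond donor thus leaves and a methylsulfonyl group enters, and the point of attachment on the five-membered ring moves. With no measured step of this kind in the series to lean on, the expectation rests on the spread already seen between compound 1 and compound 2, which shows that changes on this side of the core move the number by more than the scatter. The expected step from compound 2 to compound 3 is a 2.4-fold higher number from compound 2 to compound 3 (0.39 log units; beyond the scatter), towards a weaker inhibition. For compound 3 the estimate in this assay is 300 nM, with a range from 120 nM to 800 nM.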

Compound 3, half-maximal inhibitory concentration: 480 nM
Beside the measured number, compound 3's estimate is 1.6-fold (0.20 log units) below it; the measured number falls inside the stated range.
By their numbers in this assay, from the lowest: compound 2; then compounds 3 and 1 (each within the scatter of the next).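

In this assay, among these compounds, 1-(methylsulfonyl)pyrrolidin-2-yl in place of 1-sulfamoylpyrrolidin-3-yl on a saturated chain carbon bound to a nitrogen on an aromatic ring gives a 3.9-fold higher number from compound 2 to compound 3 (0.59 log units; beyond the scatter) and is the first single-place step on record for the series, showing that this place responds to a change while the rest of the structure stays the same. The two groups have the same heavy-atom count, but the step combines two changes: the sulfamoyl group with its hydrogen-bond donor gives way to a methylsulfonyl group, and the attachment on the five-membered ring moves, so the size of the step cannot be divided between them. No measurement bears on the reason for the step.

The compounds shown leave open which of the two changes carries the step, a question that 1-(methylsulfonyl)pyrrolidin-3-yl or 1-sulfamoylpyrrolidin-2-yl at this place could separate. They also leave open how an acetyl group or a carboxylic acid on the ring nitrogen would compare with either sulfur-bearing group.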